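Adding a methoxy group to compound 2

This account rests on a few compounds, and the source may have more. Where it says the series, first, only, none or still open, it means among the compounds named here.

Measured in an ADME assay on THP-1 cells (Homo sapiens) for cytotoxicity, read by flow cytometry and propidium iodide staining, with a stated time of 72 h; a higher number here means a weaker inhibitor, a lower number a stronger inhibitor:
Compound 1 (`COc1ccc(-c2oc3ccc(NC(C)=O)cc3c(=O)c2O)cc1`): 9000 nM
Compound 2 (`Nc1ccc2oc(-c3ccccc3)c(O)c(=O)c2c1`): 27000 nM

Of these two, compound 2 has the higher number at 27000 nM, which makes it the weaker inhibitor in this assay. Its gap to compound 1 lies beyond the scatter of repeated measurements. Compound 3 (`COc1ccc(-c2oc3ccc(N)cc3c(=O)c2O)cc1`) comes from compound 2 through one structural change: methoxy in place of hydrogen on an aromatic carbon. Going by the values given here, no measured pair shows this change alone, so its size is uncertain. Among the compounds with values here, the only lower number available is that of compound 1 at 9000 nM, so a modest fall is expected, and it may stay within the scatter. The expected change is a 1.8-fold lower number from compound 2 to compound 3 (0.26 log units; within the scatter). For compound 3 the estimated value is 15000 nM, with an expected range of 6000 nM to 32000 nM.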

Compound 3, half-maximal inhibitory concentration: 29000 nM
Compound 3: the middle estimate sits 1.9-fold (0.29 log units) below what was measured; the measured number falls inside the stated range.
By their numbers in this assay, from the lowest: compound 1; then compounds 2 and 3 (each within the scatter of the next).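

In this assay, methoxy in place of hydrogen on an aromatic carbon, para to a large group, gives a 1.1-fold higher number from compound 2 to compound 3 (0.03 log units; within the scatter), so compound 2 and compound 3 cannot be told apart and this change alone shows no measurable effect at this position. The acetyl on the nitrogen does mark a real difference: hydrogen in its place gives a 3.2-fold higher number from compound 1 to compound 3 (0.51 log units; beyond the scatter), so with methoxy present in both, the lower number of compound 1 goes with the acetyl. No measurement shown here explains either step.

From the compounds shown here alone, it remains open whether a larger group at the same place, such as ethoxy or a carboxylic acid, would also leave the number unmoved. Going by these compounds, it is equally open whether methoxy would stay without effect when the nitrogen carries acetyl, or whether a longer acyl chain there would lower the number further.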